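The source may hold more compounds than are shown below. What is called first, only, known or untested is meant among the compounds shown, and "the series" means these compounds.

In a functional assay on A-431 cells (Homo sapiens) for antiproliferative activity, read by MTT assay, with a stated time of 48 h (on this read-out lower numbers stand for stronger inhibition and higher numbers for weaker inhibition), compound 3 `COc1cc(O)c(C(=O)Nc2ccc(F)c(Cl)c2)cc1NC(=O)CCCCCC(=O)NO` gives 6460 nM, a value within the usual scatter of both compound 1 `O=C(CCCCCC(=O)Nc1ccc(O)c(C(=O)Nc2ccc(F)c(Cl)c2)c1)NO` at 3480 nM and compound 2 `C#Cc1cccc(NC(=O)c2cc(NC(=O)CCCCCC(=O)NO)ccc2O)c1` at 5750 nM. Compound 4 `C#Cc1cccc(NC(=O)c2cc(NC(=O)CCCCCC(=O)NO)c(OC)cc2O)c1` carries 3-ethynylphenyl in place of the 3-chloro-4-fluorophenyl of compound 3 on an amide-type nitrogen (3-ethynylphenyl in place of 3-chloro-4-fluorophenyl on an amide-type nitrogen). The same exchange appears in the measured set as a 1.7-fold higher number from compound 1 to compound 2 (0.22 log units; within the scatter), and methoxy in place of hydrogen on an aromatic carbon appears as a 1.9-fold higher number from compound 1 to compound 3 (0.27 log units; within the scatter). Neither step leaves the scatter, so no change beyond it is expected in this assay, only perhaps a slightly higher number. The expected step is a 1.4-fold higher number from compound 3 to compound 4 (0.14 log units; within the scatter). Compound 4 is estimated at 9000 nM, with an expected range of 4500 nM to 18000 nM.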

Compound 4, half-maximal inhibitory concentration: 4680 nM
The estimate for compound 4 lay 1.9-fold (0.28 log units) above the measured number, and the stated range covers the measured number.
By their numbers in this assay, from the lowest: compounds 1, 4, 2 and 3 (each within the scatter of the next).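

On the methoxy-bearing core of compound 3, 3-ethynylphenyl in place of 3-chloro-4-fluorophenyl on the amide-type nitrogen gives a 1.4-fold lower number from compound 3 to compound 4 (0.14 log units; within the scatter) in this assay, and the two readings of this change do not separate: the same change on two cores in this assay, a 1.7-fold higher number (0.22 log units; within the scatter) from compound 1 to compound 2 and a 1.4-fold lower number (0.14 log units; within the scatter) from compound 3 to compound 4, 2.3-fold (0.36 log units) apart, within the scatter of two such steps

Methoxy on the aromatic carbon, now read with 3-ethynylphenyl present, gives a 1.2-fold lower number from compound 2 to compound 4 (0.09 log units; within the scatter), and its two readings do not separate either: the same change on two cores in this assay, a 1.9-fold higher number (0.27 log units; within the scatter) from compound 1 to compound 3 and a 1.2-fold lower number (0.09 log units; within the scatter) from compound 2 to compound 4, 2.3-fold (0.36 log units) apart, within the scatter of two such steps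

Thus neither change leaves the scatter on either core.

From the compounds shown here alone, whether an amine or a carboxylic acid in place of the methoxy, or a nitrile in place of the ethynyl, would move the number beyond the scatter remains open.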